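Benzyl in place of the side group of compound 2

A few compounds are considered here, and "the series" means these few. Any claim that something is new, unique, unknown or untested is made for them only; others in the source may bear on it.

In a functional assay for inhibition, with Homo sapiens as the target (a lower number here means tighter binding, a higher number weaker binding), compound 1 `O=C(O)CC/C=C\CC1COC(c2ccc(C(F)(F)F)cc2)OC1c1cccnc1` gives 1780 nM and compound 2 `CC(C)(Oc1ccc(F)cc1[N+](=O)[O-])C1OCC(C/C=C\CCC(=O)O)C(c2cccnc2)O1` gives 2.51 nM, the lower of the two numbers and beyond the scatter. Compound 3 `CC(C)(Cc1ccccc1)C1OCC(C/C=C\CCC(=O)O)C(c2cccnc2)O1` has a group of 7 heavy atoms (7 carbon; one six-membered aromatic ring of carbon only) in place of a group of 11 heavy atoms (6 carbon, 1 nitrogen, 3 oxygen, 1 fluorine; one six-membered aromatic ring of carbon only), on a saturated chain carbon bound to two saturated chain carbons and a saturated ring carbon. Both groups hold one six-membered aromatic ring of carbon only. Among the compounds with values here, no measured step covers this change, so any size in this assay is a judgement from the structures alone. A move to a higher number, beyond the scatter, is expected: a 10-fold higher number from compound 2 to compound 3 (1.00 log units; beyond the scatter). Compound 3 is estimated at 25 nM, with an expected range of 4 nM to 150 nM.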

Compound 3, dissociation constant: 513 nM
Compound 3: the middle estimate sits 21-fold (1.31 log units) below what was measured, outside the stated range (above it).
By their numbers in this assay, from the lowest: compound 2; then compound 3; then compound 1.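

In this assay, a 200-fold higher number from compound 2 to compound 3 (2.31 log units; beyond the scatter), so an aromatic ring of carbon only on this saturated chain carbon is not enough to keep the low number of compound 2. The same group still gives a measurable improvement over the 4-(trifluoromethyl)phenyl arrangement: a 3.5-fold lower number from compound 1 to compound 3 (0.54 log units; beyond the scatter). No available evidence accounts for the size of either step.

Which part of the departing group matters remains open. An unsubstituted phenoxy group or a nitrobenzyl group at this place would separate the contribution of the ether oxygen from that of the ring substituents.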